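A few compounds are considered here, and "the series" means these few. Any claim that something is new, unique, unknown or untested is made for them only; others in the source may bear on it.

Measured compounds:
- compound 1, `CNc1nc(C)c(C(=O)N/N=C/c2ccccc2C(F)(F)F)s1`: > 100 ug/mL
- compound 2, `CN(C(=O)NC(=O)c1cccc(C(F)(F)F)c1)c1nc(C(F)(F)F)c(C(=O)N/N=C/c2ccc(C(F)(F)F)cc2)s1`: 7.35 ug/mL
- compound 3, `CN(C(=O)NC(=O)c1ccccc1F)c1nc(C(F)(F)F)c(C(=O)N/N=C/c2cc(C(F)(F)F)cc(C(F)(F)F)c2)s1`: 4.98 ug/mL

Of the compounds shown here, three have been measured in a functional assay on HeLa cells (Homo sapiens) for inhibition, read by MTT assay, with a stated time of 72 h; on this read-out lower numbers stand for stronger inhibition and higher numbers for weaker inhibition. For compound 1 the result is only a limit of the assay, (the limit of > 100 ug/mL in this assay, at which 1 of the 3 values shown sits), not a number. Compound 2 and compound 3 both give numbers; compound 3 has the lower of the two, but its gap to compound 2 lies within the scatter, so the two cannot be told apart.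

Compound 4, `CN(C(=O)NC(=O)c1ccc(F)c(F)c1)c1nc(C(F)(F)F)c(C(=O)N/N=C/c2cc(C(F)(F)F)cc(C(F)(F)F)c2)s1`, is the next compound to consider. It differs from compound 3 in one place: 3,4-difluorophenyl in place of 2-fluorophenyl on a carbonyl carbon. Within the data shown here, no measured pair in this set differs in the same way, so the size of this step has no direct precedent here. Since both fluorinated variants carry the same shared core and the change is confined to the fluorine count and placement on one ring, the expected step from compound 3 to compound 4 is a 1.0-fold higher number from compound 3 to compound 4 (0.00 log units; within the scatter), within the usual scatter in either direction. On that basis compound 4 is expected to give about 5 ug/mL in this assay, with a likely range from 2.5 ug/mL to 10 ug/mL.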

Compound 4, half-maximal inhibitory concentration: 4.45 ug/mL
Compound 4: middle estimate off by 1.1-fold (0.05 log units), on the high side; the measured number falls inside the stated range.
By their numbers in this assay, from the lowest: compounds 4, 3 and 2 (each within the scatter of the next). At a limit, above all of these: compound 1.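

Going from 2-fluorophenyl to 3,4-difluorophenyl on a carbonyl carbon gives a 1.1-fold lower number from compound 3 to compound 4 (0.05 log units; within the scatter) in this assay, so the two compounds cannot be told apart. Among these compounds, this is the first pair in the set that differs in only one place, and so the first direct reading of this position: a second fluorine and a new fluorine placement on this ring produce no step that stands clear of the scatter. Nothing measured here bears on the reason for this result.

From the compounds shown here alone, both rings tested at this position are fluorinated phenyl groups, so it remains open whether a phenyl ring carrying an amine or a carboxylic acid, or a longer chain in place of the ring, would give a similar number. Going by these compounds, it is also open whether these two groups would stay this close on a different core.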